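The source may hold more compounds than are shown below. What is called first, only, known or untested is meant among the compounds shown, and "the series" means these compounds.

Among the measured compounds shown here, compound 2 `O=C(OC/C(=C\C1CCCCC1)C(=O)c1ccccc1)c1ccccc1` gives 23000 nM in a functional assay on HBL-100 cells (Homo sapiens) for inhibition, read by sulforhodamine B assay, with a stated time of 48 h (on this read-out lower numbers stand for stronger inhibition of growth and higher numbers for weaker inhibition of growth), the highest of the two numbers measured so far; its nearest neighbour, compound 1 `CC(=O)OC/C(=C\C1CCCCC1)C(=O)c1ccccc1`, gives 21000 nM. For the measured compounds named here, the only measured step, a 1.1-fold higher number from compound 1 to compound 2 (0.04 log units; within the scatter), alters a group on a carbonyl carbon and leaves the double-bonded chain carbon untouched. Compound 3 `O=C(OC/C(=C\c1ccccc1[N+](=O)[O-])C(=O)c1ccccc1)c1ccccc1` differs from compound 2 by 2-nitrophenyl in place of cyclohexyl on a double-bonded chain carbon bound to a double-bonded chain carbon. Going by the values given here, no measured step bears on that place, so nothing in the data points to a shift beyond the scatter in this assay. Compound 3 is therefore estimated at 20000 nM, with a range from 5000 nM to 80000 nM. The expected step of a 1.2-fold lower number from compound 2 to compound 3 (0.06 log units; within the scatter) is small, an estimate resting only on the absence of any relevant comparison.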

Compound 3, concentration for 50% growth inhibition: 3900 nM
Compound 3: the middle estimate sits 5.1-fold (0.71 log units) above what was measured; measured number outside the range, below it.
By their numbers in this assay, from the lowest: compound 3; then compounds 1 and 2 (each within the scatter of the next).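

In this assay, the double-bonded chain carbon bound to a double-bonded chain carbon proves responsive: 2-nitrophenyl in place of cyclohexyl gives a 5.9-fold lower number from compound 2 to compound 3 (0.77 log units; beyond the scatter), whereas the change on the carbonyl carbon, a 1.1-fold higher number from compound 1 to compound 2 (0.04 log units; within the scatter), did not move the number beyond the scatter. Growth inhibition therefore strengthens with this change, the first step shown to do so. No evidence is available that explains this step. The step replaces cyclohexyl with an aromatic ring and brings in a nitro group together, so the two remain unseparated. As far as these compounds go, whether plain phenyl or an aminophenyl group at this place would match compound 3 stays open.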